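A few compounds are considered here, and "the series" means these few. Any claim that something is new, unique, unknown or untested is made for them only; others in the source may bear on it.

Compound 3 `CC(C)(C)OC(=O)/C(C#N)=C/c1ccc(O)c(O)c1` was tested in a functional assay on the whole organism (strain CD1) for inhibition, with Mus musculus as the target, with stated times of 15 min and 20 min, at a dose of 10 mg/kg by the subcutaneous route (a higher number here means more inhibition at the dose given (going by the name of the read-out), a lower number less inhibition), and gave 43.4%. Two companions set the frame. Compound 1 `NC/C(=C\c1ccc(O)c(O)c1)C(=O)O` carries an aminomethyl group on the double-bonded chain carbon and gives, in this assay, 50.1%, a number that lies within the usual scatter of the result for compound 3. Compound 2 `O=C(O)/C(F)=C/c1ccc(O)c(O)c1`, with fluoro in that same place, gives -5.8%; the step of a number 55.9 percentage points lower from compound 1 to compound 2 (beyond the scatter) is large and well beyond the scatter. Compound 3 therefore stands close to compound 1 and far above compound 2 on the three numbers shown.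

Compound 4 `N#C/C(=C\c1ccc(O)c(O)c1)C(=O)OC1CCCCC1` differs from compound 3 in one place: cyclohexyl in place of tert-butyl on an oxygen next to a carbonyl group. Among the measured compounds shown here, none of the measured steps touches this ester oxygen; the only documented change, from compound 1 to compound 2, concerns the group on the chain carbon, so it says nothing direct about swapping one alkyl ester for another. For the measured compounds named here, with no step bearing on the change, there is no basis to expect a shift beyond the scatter in this assay in either direction. Compound 4 is accordingly expected to give about 40%, with a range from 15% to 65%. The step of a number 3.4 percentage points lower from compound 3 to compound 4 (within the scatter) is expected to be small, within the scatter.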

Compound 4, a percentage reported as inhibition, in the whole organism at one dose (the size of the read-out at that dose, not a potency): 55.3%
Beside the measured number, compound 4's estimate is 15.3 percentage points below it; the range from low to high includes it.
By their numbers in this assay, from the lowest: compound 2; then compounds 3, 1 and 4 (each within the scatter of the next, the first and the last beyond it).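

Among the compounds shown here, the ester position, which none of the earlier steps touched, turns out to matter in this assay: cyclohexyl in place of tert-butyl on an oxygen next to a carbonyl group gives a number 11.9 percentage points higher from compound 3 to compound 4 (beyond the scatter) and so moves the read-out by a modest amount. This change swaps one carbon-only group for another, adding a six-membered non-aromatic ring and more carbon while bringing in no hydrogen-bond donor, no hydrogen-bond acceptor and no net charge, so a change of that kind alone is enough for a step of this size between these two compounds. Nothing in the information available explains why the cyclohexyl ester reads higher than the tert-butyl ester.

This single pair cannot separate the contribution of the ring from that of the added carbon, and an open-chain hexyl group on the same oxygen would be needed to tell the two apart. The compounds shown also leave open how a small methyl ester, or a free carboxylic acid in place of the ester with the nitrile kept on the chain carbon, would compare with compound 3 and compound 4.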